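Removing the Hydroxyl: A Neopentyl Analogue of Compound 3

The source may report more compounds than this note shows. Statements on the series, on what has been measured and on what is new or still open speak of the compounds shown alone.

Of the compounds shown here, three have been measured in an assay on cell membranes for binding affinity to adenosine receptor A1 (Cavia porcellus), read by radioligand binding; on this read-out lower numbers stand for stronger inhibition and higher numbers for weaker inhibition. Compound 1 `CCC(CC)Nc1ncnc2c1ncn2C1O[C@H](CO)[C@@H](O)[C@H]1O` gives 0.75 nM. Compound 2 `CCCn1c(=O)c2nc([C@@H]3CC4C=CC3C4)[nH]c2n(CCC)c1=O` gives 4.3 nM. Compound 3 `CCCn1c(=O)c2nc(C(C)(O)CC)[nH]c2n(CCC)c1=O` gives 240 nM, the highest of the three numbers, with compound 2 nearest and compound 1 furthest away. Going by the values given here, the only single-point change among them runs a 56-fold higher number from compound 2 to compound 3 (1.75 log units; beyond the scatter), so swapping an all-carbon ring group for an oxygen-bearing chain on that aromatic carbon cost a great deal of binding.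

Compound 4 `CCCn1c(=O)c2nc(CC(C)(C)C)[nH]c2n(CCC)c1=O` takes the next step: neopentyl in place of 1-hydroxy-1-methylpropyl on an aromatic carbon. The carbon count stays the same, but the hydrogen-bond donor and acceptor of the leaving group disappear, and what enters is a branched chain rather than a ring.

Among the compounds with values here, no measured step is a direct match. The step from compound 2 to compound 3 does bear on it, since it shows that an all-carbon group on this position gave the lower number, but compound 2 carried a ring system, not a chain, so only part of that gain is likely to return. Compound 4 is therefore expected to show a 4.0-fold lower number from compound 3 to compound 4 (0.60 log units; beyond the scatter), a moderate drop toward compound 2 without reaching it. The estimate for compound 4 in this assay is 60 nM, with a range from 15 nM to 250 nM.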

Compound 4, inhibition constant: 49 nM
For compound 4 the middle estimate is 1.2-fold (0.09 log units) above the measured one; the measured number falls inside the stated range.
By their numbers in this assay, from the lowest: compound 1; then compound 2; then compound 4; then compound 3.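

In this assay, the swap of 1-hydroxy-1-methylpropyl for neopentyl gives a 4.9-fold lower number from compound 3 to compound 4 (0.69 log units; beyond the scatter). Both groups have the same count of heavy atoms and no ring, so on this aromatic carbon a chain of carbon alone gives a lower number than the chain carrying a hydroxyl. The neopentyl chain still falls well short of the ring group, at an 11-fold higher number from compound 2 to compound 4 (1.06 log units; beyond the scatter), which shows that an all-carbon group recovers only part of the loss seen with compound 3, and no measurement on hand says why either step turns out as it does.

From the compounds shown here alone, what the hydroxyl contributes by itself stays open, since this swap also rearranges the carbons of the chain, and a 1-methylpropyl group, the leaving chain without its hydroxyl, would separate those two changes. Also open, going by these compounds, is whether a simple single ring of carbon such as cyclopentyl, in the same place, would bring the number closer to that of compound 2 than neopentyl does.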